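From 1-propanoylpiperidin-4-yl to 1-methylpiperidin-4-yl on the sulfonyl sulfur

The source may report more compounds than this note shows. Statements on the series, on what has been measured and on what is new or still open speak of the compounds shown alone.

- compound 1 `CCCn1cc(S(=O)(=O)c2ccc(CNC(=O)N3Cc4ccncc4C3)cc2)cn1` gives 7.3 nM in a functional assay on A2780 cells (Homo sapiens) for cytotoxicity, read by sulforhodamine B assay, with a stated time of 72 h; a lower number here means a stronger inhibitor, a higher number a weaker inhibitor
- compound 2 `CCC(=O)N1CCC(S(=O)(=O)c2ccc(CNC(=O)N3Cc4ccncc4C3)cc2)CC1` gives 54 nM in this assay

Among the compounds with values here, compound 2 holds the higher of the two numbers in this assay so far. Next comes compound 3 `CN1CCC(S(=O)(=O)c2ccc(CNC(=O)N3Cc4ccncc4C3)cc2)CC1`, with methyl in place of propanoyl on an amine nitrogen in a ring. Within the data shown here, the only measured step is a 7.4-fold higher number from compound 1 to compound 2 (0.87 log units; beyond the scatter), with 1-propanoylpiperidin-4-yl in place of 1-propyl-1H-pyrazol-4-yl on the sulfonyl sulfur. Among the measured compounds shown here, it shows that a change of this substituent can shift the number by a modest amount, but no measured step isolates the loss of propanoyl. A modest shift towards a higher number is therefore expected, though the direction is uncertain. The expected change is a 1.7-fold higher number from compound 2 to compound 3 (0.22 log units; within the scatter) and no more than that. For compound 3 the estimate is 90 nM, with an expected range of 18 nM to 450 nM in this assay.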

Compound 3, half-maximal inhibitory concentration: 99 nM
Compound 3: the middle estimate sits 1.1-fold (0.04 log units) below what was measured, within the range that was stated.
By their numbers in this assay, from the lowest: compound 1; then compounds 2 and 3 (each within the scatter of the next).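

In this assay, within the data shown here, the step of a 1.8-fold higher number from compound 2 to compound 3 (0.26 log units; within the scatter) is the first to isolate the substituent on the amine nitrogen of the ring, and it does not separate methyl from propanoyl. The step of a 14-fold higher number from compound 1 to compound 3 (1.13 log units; beyond the scatter) places 1-methylpiperidin-4-yl, like 1-propanoylpiperidin-4-yl before it, beyond the scatter from 1-propyl-1H-pyrazol-4-yl on the sulfonyl sulfur, so the gap to compound 1 now holds for two different substituents on that nitrogen. No supporting measurement bears on these numbers.

Still open, going by these compounds, is whether a longer acyl chain, a benzoyl group or a free ring amine at that nitrogen would move the number beyond the scatter. The compounds shown also leave open whether a methyl group in place of the propyl chain on the pyrazole would keep the value of compound 1.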